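Piperidine to methylpiperazine on a tetrahydroquinoline quinazoline

The compounds below may be only part of what the source reports. "The series", "measured", "known", "first", "only" and "open" are said of these compounds alone.

Compound 1 `COc1cc2ncnc(N3CCc4ccccc43)c2cc1NC(=O)/C=C/CN1CCCCC1`: 1680 nM
Compound 2 `COc1cc2ncnc(N3CCc4ccccc43)c2cc1NC(=O)/C=C/CN1CCN(C)CC1`: 6430 nM
Compound 3 `COc1cc2ncnc(N3CCCc4ccccc43)c2cc1NC(=O)/C=C/CN1CCCCC1`: 3930 nM

Three compounds were tested in a functional assay on MCF7 cells (Homo sapiens) for antiproliferative activity, read by MTT assay, with a stated time of 72 h; on this read-out higher numbers stand for weaker inhibition and lower numbers for stronger inhibition. Compound 1 gives 1680 nM. Compound 2 differs by 4-methylpiperazin-1-yl in place of piperidin-1-yl on a saturated chain carbon bound to a double-bonded chain carbon, and the step of a 3.8-fold higher number from compound 1 to compound 2 (0.58 log units; beyond the scatter) follows. Compound 3 carries a different core, (1,2,3,4-tetrahydroquinolin-1-yl in place of 2,3-dihydro-1H-indol-1-yl on an aromatic carbon), and the step of a 2.3-fold higher number from compound 1 to compound 3 (0.37 log units; beyond the scatter) results. Compound 4 `COc1cc2ncnc(N3CCCc4ccccc43)c2cc1NC(=O)/C=C/CN1CCN(C)CC1` is not yet measured; it differs from compound 3 by 4-methylpiperazin-1-yl in place of piperidin-1-yl on a saturated chain carbon bound to a double-bonded chain carbon, the same change as that from compound 1 to compound 2, made at the same place. Compound 4 is therefore expected to show a step of a 3.3-fold higher number from compound 3 to compound 4 (0.52 log units; beyond the scatter), beside the earlier one. Among the compounds with values here, this expectation rests on compound 1 and compound 2, because a 3.8-fold higher number from compound 1 to compound 2 (0.58 log units; beyond the scatter) is the only measured instance of the change. Compound 4 is estimated at 13000 nM, between 6000 nM and 30000 nM.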

Compound 4, half-maximal inhibitory concentration: 8560 nM
Compound 4: the middle estimate sits 1.5-fold (0.18 log units) above what was measured; the measured number falls inside the stated range.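

In this assay putting 4-methylpiperazin-1-yl in place of piperidin-1-yl on the second core gives a 2.2-fold higher number from compound 3 to compound 4 (0.34 log units; beyond the scatter) and this step does not differ from the one on the first core: the same change on two cores in this assay, a 3.8-fold higher number (0.58 log units; beyond the scatter) from compound 1 to compound 2 and a 2.2-fold higher number (0.34 log units; beyond the scatter) from compound 3 to compound 4, 1.8-fold (0.24 log units) apart, within the scatter of two such steps. The core change, read on the 4-methylpiperazin-1-yl compounds, gives a 1.3-fold higher number from compound 2 to compound 4 (0.12 log units; within the scatter) and this too stays in line with its earlier instance: the same change on two cores in this assay, a 2.3-fold higher number (0.37 log units; beyond the scatter) from compound 1 to compound 3 and a 1.3-fold higher number (0.12 log units; within the scatter) from compound 2 to compound 4, 1.8-fold (0.24 log units) apart, within the scatter of two such steps. The piperidine change thus carried over in direction and, within the scatter, in size, but two pairs on two cores do not show that it would carry to any further core.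

The compounds shown leave open whether a morpholin-4-yl or dimethylamino group on the same saturated chain carbon would behave alike. They also leave open whether a longer chain carrying the amine would preserve these steps.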